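This account rests on a few compounds, and the source may have more. Where it says the series, first, only, none or still open, it means among the compounds named here.

Compound 2 `CCCCCc1ccc(-c2cn(C[C@H](O)[C@H]3OC(=O)C(OCc4ccccc4)=C3OCc3ccccc3)nn2)cc1` is one of two compounds whose antiproliferative activity has been determined in a functional assay on HepG2 cells (Homo sapiens) for antiproliferative activity, read by MTT assay, with a stated time of 72 h; a lower number here means a stronger inhibitor, a higher number a weaker inhibitor. There compound 2 gives 7460 nM, the higher of the two numbers, while compound 1 `O=C1O[C@H]([C@@H](O)Cn2cc(-c3ccc(Br)cc3)nn2)C(OCc2ccccc2)=C1OCc1ccccc1` gives 5070 nM. Within the data shown here, the only step between measured compounds, a 1.5-fold higher number from compound 1 to compound 2 (0.17 log units; within the scatter), puts pentyl in place of bromo on an aromatic carbon and stays within the scatter. Compound 3 `COc1ccccc1-c1cn(C[C@H](O)[C@H]2OC(=O)C(OCc3ccccc3)=C2OCc2ccccc2)nn1` has not yet been measured. It differs from compound 2 by 2-methoxyphenyl in place of 4-pentylphenyl on an aromatic carbon. Among the measured compounds shown here, the single measured step that touches this part of the molecule, a 1.5-fold higher number from compound 1 to compound 2 (0.17 log units; within the scatter), was within the scatter, so no step beyond the scatter is expected in this assay from compound 2 to compound 3, although the entering group carries an oxygen and a hydrogen-bond acceptor that nothing measured speaks to. Compound 3 is therefore expected to give 6500 nM, with a range from 2500 nM to 17000 nM. The step this estimate implies is a 1.1-fold lower number from compound 2 to compound 3 (0.06 log units; within the scatter).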

Compound 3, half-maximal inhibitory concentration: > 100000 nM
Compound 3 gave a limit, no number (the forecaster's own chance of this, stated with the estimate: 5%); at least 15-fold (1.18 log units) between middle value and limit.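

Compound 3 stands at a limit of the assay, not at a number: the limit of > 100000 nM in this assay, at which 1 of the 3 values shown sits. The earlier compounds shown here showed only that 4-bromophenyl and 4-pentylphenyl read alike in this assay, which left this aromatic carbon of the five-membered aromatic ring with 3 nitrogen looking undemanding. The change to 2-methoxyphenyl shows otherwise, with an at least 13-fold higher number from compound 2 to compound 3 (1.12 log units; beyond the scatter) and an at least 19-fold higher number from compound 1 to compound 3 (1.29 log units; beyond the scatter), so the group at this position can decide whether any activity is seen at all in this assay.

The compounds shown do not tell whether this loss follows the oxygen of the methoxy group or the place of that group on the phenyl ring. On these data alone, how an amine or a carboxylic acid on that phenyl ring would read also stays open.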